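A few compounds are considered here, and "the series" means these few. Any claim that something is new, unique, unknown or untested is made for them only; others in the source may bear on it.

Among the compounds with values here, compound 3 `Oc1cccc(-c2cc(-c3ccccc3C(F)(F)F)cc(-c3ccccc3O)n2)c1` supplies the only number. In a functional assay on HeLa cells (Homo sapiens) for inhibition (a higher number here means a weaker inhibitor, a lower number a stronger inhibitor), compound 3 gives 16800 nM. Compound 1 `Oc1cccc(-c2cc(-c3cccc(F)c3)cc(-c3ccccc3O)n2)c1` reports only a limit, > 50000 nM in this assay. Compound 2 `Oc1ccccc1-c1cc(-c2cccc(C(F)(F)F)c2)cc(-c2ccccc2O)n1` likewise reports only a limit, > 50000 nM. Within the data shown here, compound 3 therefore stands alone as the single compound with a measurable value; the other two sit at the limit of > 50000 nM in this assay, at which 2 of the 3 values shown sit.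

The next compound, compound 4 `Oc1cccc(-c2cc(-c3cccc(C(F)(F)F)c3)cc(-c3ccccc3O)n2)c1`, differs from compound 3 by 3-(trifluoromethyl)phenyl in place of 2-(trifluoromethyl)phenyl on an aromatic carbon. Among the measured compounds shown here, one measured step bears on this change: an at least 2.9-fold lower number from compound 1 to compound 3 (0.47 log units; beyond the scatter), where 2-(trifluoromethyl)phenyl in place of 3-fluorophenyl moved the number off the limit. Compound 4 reverses the arrangement, carrying 3-(trifluoromethyl)phenyl, the same group present in compound 2, which reports a limit only. On that basis the move from 2-(trifluoromethyl)phenyl to 3-(trifluoromethyl)phenyl is expected to push the number back toward the limit, a weakening step estimated as a 2.7-fold higher number from compound 3 to compound 4 (0.43 log units; beyond the scatter) in this assay. Compound 4 is accordingly expected to give about 45000 nM in this assay, with a plausible range from 15000 nM to 130000 nM, and a real chance that only a limit is reported.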

Compound 4, half-maximal inhibitory concentration: 19500 nM
For compound 4 the middle estimate is 2.3-fold (0.36 log units) above the measured one; low and high end bracket the measured number.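

Moving the trifluoromethyl group on this phenyl ring, which sits opposite the ring nitrogen, does not separate the two compounds in this assay: a 1.2-fold higher number from compound 3 to compound 4 (0.06 log units; within the scatter). At this place, with the 3-hydroxyphenyl group kept, 2-(trifluoromethyl)phenyl and 3-(trifluoromethyl)phenyl therefore cannot be told apart, so the earlier step away from 3-fluorophenyl does not depend on where the trifluoromethyl group stands. With 3-(trifluoromethyl)phenyl held fixed, the other two single changes both matter, an at least 2.5-fold lower number from compound 2 to compound 4 (0.40 log units; beyond the scatter) for 3-hydroxyphenyl in place of 2-hydroxyphenyl and an at least 2.5-fold lower number from compound 1 to compound 4 (0.40 log units; beyond the scatter) for trifluoromethyl in place of fluoro, although each starts from a limit and gives only a minimum size: the limit of > 50000 nM in this assay, at which 2 of the 4 values shown sit.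

Going by these compounds, whether a methoxy, an amine or a carboxylic acid in place of trifluoromethyl on this phenyl ring would move the number away from that of compound 3 and compound 4 stays open. Also open, on these data alone, is how far the true sizes of the two steps from the limit reach, and whether a methoxy in place of the hydroxyl on the 3-hydroxyphenyl group would keep the gain seen over compound 2.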